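This account rests on a few compounds, and the source may have more. Where it says the series, first, only, none or still open, it means among the compounds named here.

Series notes. Compound 1 `CN(C)CCn1cnnc1-c1cc(Oc2ccc(NC(=O)N/N=C/c3cc(C(C)(C)C)cc(C(C)(C)C)c3O)cc2F)ccn1` gives 3300 nM in a functional assay on MKN-45 cells (Homo sapiens) for cytotoxicity, read by MTT assay, with a stated time of 72 h; on this read-out higher numbers stand for weaker inhibition and lower numbers for stronger inhibition. Compound 2 `CN(C)CCn1cnnc1-c1cc(Oc2ccc(NC(=O)N/N=C/c3ccc(O)c(Br)c3)cc2F)ccn1` gives 1860 nM in this assay; compound 2 and compound 1 sit within the scatter of each other, so no order between them is read, and compound 2 carries the lowest of the two numbers shown. Compound 3 `Cn1ncnc1-c1cc(Oc2ccc(NC(=O)N/N=C/c3ccccc3)cc2F)ccn1` reaches only the limit > 100000 nM in this assay, that is the limit of > 100000 nM in this assay, at which 1 of the 3 values shown sits, and gives no number. Compound 4 `COc1cc(/C=N/NC(=O)Nc2ccc(Oc3ccnc(-c4nncn4CCN(C)C)c3)c(F)c2)cc(OC)c1OC` is not yet measured; it differs from compound 2 by 3,4,5-trimethoxyphenyl in place of 3-bromo-4-hydroxyphenyl on a carbon with a double bond to nitrogen. Among the compounds with values here, no measured pair isolates this change, so the direction rests on judgement alone. The step from compound 2 to compound 4 is expected to be a 4.3-fold higher number from compound 2 to compound 4 (0.63 log units; beyond the scatter) in this assay, towards weaker inhibition. Compound 4 is accordingly estimated at 8000 nM, with a range from 2000 nM to 40000 nM.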

Compound 4, half-maximal inhibitory concentration: 2900 nM
The estimate for compound 4 lay 2.8-fold (0.44 log units) above the measured number, and the stated range covers the measured number.
By their numbers in this assay, from the lowest: compounds 2, 4 and 1 (each within the scatter of the next). At a limit, above all of these: compound 3.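

At this place, on a carbon with a double bond to nitrogen, 3,4,5-trimethoxyphenyl in place of 3-bromo-4-hydroxyphenyl gives a 1.6-fold higher number from compound 2 to compound 4 (0.19 log units; within the scatter) in this assay. Within the data shown here, the single change therefore leaves the two compounds unseparated, even though the hydrogen-bond donor and the bromine leave and the entering group has more heavy atoms. Nothing measured here gives a cause for this step.

As far as these compounds go, the bromine and the hydroxyl leave together, so their separate contributions stay open. Also open, from the compounds shown here alone, is how an amine or a carboxylic acid on this phenyl ring would read in this assay.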